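Swapping an aryl group for a benzamidomethyl arm

This account rests on a few compounds, and the source may have more. Where it says the series, first, only, none or still open, it means among the compounds named here.

Measured so far:
Compound 1 `Cc1ccc(-c2nnc(SCCCN3CCN(c4nc5ccccc5o4)CC3)o2)cc1` — 133000 nM
Compound 2 `CC(C)(C)Oc1ccc(-c2nnc(SCCCN3CCN(c4nc5ccccc5o4)CC3)o2)cc1` — 269000 nM

In a functional assay on HeLa cells (Homo sapiens) for inhibition, read by MTT assay, with a stated time of 72 h (a higher number here means a weaker inhibitor, a lower number a stronger inhibitor), compound 2 gives the highest of the two numbers; its nearest neighbour is compound 1, and the step of a 2.0-fold higher number from compound 1 to compound 2 (0.31 log units; beyond the scatter) separates them. Compound 3 `O=C(NCc1nnc(SCCCN2CCN(c3nc4ccccc4o3)CC2)o1)c1ccccc1` differs from compound 2 by benzamidomethyl in place of 4-(tert-butoxy)phenyl on an aromatic carbon. Among the measured compounds shown here, no measured step covers a change of this kind; the only known step, from tert-butoxy to methyl, is modest and concerns a different part of the molecule. The direction is therefore open, and a wide range is expected. For compound 3 the estimate in this assay is 200000 nM, between 60000 nM and 600000 nM, meaning a step of a 1.3-fold lower number from compound 2 to compound 3 (0.13 log units; within the scatter) is expected.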

Compound 3, half-maximal inhibitory concentration: 63900 nM
Compound 3: the middle estimate sits 3.1-fold (0.50 log units) above what was measured, within the range that was stated.
By their numbers in this assay, from the lowest: compound 3; then compound 1; then compound 2.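

This position of the shared core accepts more than a directly attached substituted phenyl: in this assay, the benzamidomethyl arm, with its amide hydrogen, gives a 4.2-fold lower number from compound 2 to compound 3 (0.62 log units; beyond the scatter) and also a 2.1-fold lower number from compound 1 to compound 3 (0.32 log units; beyond the scatter) in the same direction. Both steps are modest, and compound 3 still gives 63900 nM as a weak inhibitor. No measurement explains the gain.

The compounds shown leave open whether the amide itself matters or only the changed arm, and whether a longer chain in the arm, or an amine or carboxylic acid on its ring, would lower the number further.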